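The compounds below may be only part of what the source reports. "The series", "measured", "known", "first", "only" and "open" are said of these compounds alone.

In a functional assay on the whole organism (strain Wistar) for inhibition, with Rattus norvegicus as the target, read by paw edema, with stated times of 60 min and 24 h, at a dose of 100 mg/kg by the oral route (on this read-out higher numbers stand for more inhibition at the one dose given (going by the name of the read-out) and lower numbers for less inhibition), compound 2 `CCNC(=O)CC1CCc2cc(OC)c(OC)cc21` gives 33.3% and stands level with compound 1 `CNC(=O)CC1CCc2cc(OC)c(OC)cc21`, which gives 33.3%. Going by the values given here, the single measured step, no change at the digits printed from compound 1 to compound 2 (within the scatter), was a change of methyl in place of hydrogen on the saturated chain carbon bound to the amide-type nitrogen. Compound 3 `CCCNC(=O)CC1CCc2cc(OC)c(OC)cc21` carries the same kind of change one bond further out: methyl in place of hydrogen on a saturated chain carbon, two bonds along the chain from an amide-type nitrogen. Among the compounds with values here, since the one comparable step showed no change within the scatter, no step beyond the scatter is expected in this assay, a number 0.3 percentage points lower from compound 2 to compound 3 (within the scatter). Compound 3 is therefore estimated at 33%, expected to lie between 20% and 46%.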

Compound 3, a percentage reported as inhibition, in the whole organism at one dose (the size of the read-out at that dose, not a potency): 26.7%
Compound 3: the middle estimate sits 6.3 percentage points above what was measured; low and high end bracket the measured number.
By their numbers in this assay, from the lowest: compounds 3, 1 and 2 (each within the scatter of the next).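

In this assay methyl in place of hydrogen two bonds along the chain from the amide-type nitrogen gives a number 6.6 percentage points lower from compound 2 to compound 3 (within the scatter) and ethyl in place of hydrogen on the saturated chain carbon bound to that nitrogen gives a number 6.6 percentage points lower from compound 1 to compound 3 (within the scatter) over the two changes together. The further position thus behaves like the earlier one, and even the summed change from methyl to propyl on the nitrogen stays within the scatter. No measurement shown accounts for these numbers. From the compounds shown here alone, whether a butyl chain, a phenyl group or a carboxylic acid in place of this chain would give a step beyond the scatter remains open. So does whether the secondary amide could be replaced by an amine.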